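Hydroxyphenyl position on the shared core, cytotoxicity

This account rests on a few compounds, and the source may have more. Where it says the series, first, only, none or still open, it means among the compounds named here.

Measured so far:
compound 1 `Oc1ccc(-c2cc(-c3cccs3)cc(-c3ccccc3O)n2)cc1` — > 50000 nM
compound 2 `Oc1ccccc1-c1cc(-c2ccco2)cc(-c2ccccc2O)n1` — > 50000 nM
compound 3 `Oc1cccc(-c2cc(-c3ccco3)cc(-c3ccccc3O)n2)c1` — 1790 nM

In a functional assay on DU-145 cells (Homo sapiens) for cytotoxicity, read by CCK-8 assay (on this read-out lower numbers stand for stronger inhibition and higher numbers for weaker inhibition), compound 1 reaches only a limit, > 50000 nM. Compound 2 likewise gives a limit in this assay, > 50000 nM. Among the compounds with values here, compound 3 is the one compound with a number, 1790 nM, so it stands as the only measured point. Within the data shown here, the step of an at least 27-fold lower number from compound 2 to compound 3 (1.44 log units; beyond the scatter) is the single measured step and shows the hydroxyl position governs the read-out strongly, with the limit of > 50000 nM in this assay, at which 2 of the 3 values shown sit, marking where the other values rest.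

Compound 4 `Oc1ccc(-c2cc(-c3ccco3)cc(-c3ccccc3O)n2)cc1` is not yet measured. It differs from compound 3 by 4-hydroxyphenyl in place of 3-hydroxyphenyl on an aromatic carbon. Compound 1 also carries a 4-hydroxyphenyl group and sits at the limit, so a weakening is expected; compound 4 is estimated at 20000 nM (range 4000 nM to 100000 nM), a step of an 11-fold higher number from compound 3 to compound 4 (1.05 log units; beyond the scatter) expected in this assay.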

Compound 4, half-maximal inhibitory concentration: > 50000 nM
Compound 4: only a limit was reported (the forecaster's own chance of this, stated with the estimate: 50%); middle value at least 2.5-fold (0.39 log units) away from the limit.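

With furan-2-yl held fixed, all three hydroxyphenyl groups have now been seen at this position, and only the 3-hydroxyphenyl group of compound 3 gives a number in this assay; the change to 4-hydroxyphenyl gives an at least 27-fold higher number from compound 3 to compound 4 (1.44 log units; beyond the scatter). The steps to compound 4 from compound 2 and from compound 1 cannot be read, so furan-2-yl and thiophen-2-yl remain unseparated with 4-hydroxyphenyl. Compound 3 alone stands clear of the shared limit: the limit of > 50000 nM in this assay, at which 3 of the 4 values shown sit.

Open, on these data alone, is whether thiophen-2-yl keeps a number alongside 3-hydroxyphenyl. Also open, as far as these compounds go, is whether 3-methoxyphenyl or 3-aminophenyl at this position does.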